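From Compound 3 to Compound 4 in a Growth Assay

This account rests on a few compounds, and the source may have more. Where it says the series, first, only, none or still open, it means among the compounds named here.

Compound 1 `CC(=O)c1ccc(/C=C(/Sc2ccc(C)cc2)C(=O)c2ccc(Br)cc2)cc1` gives 50000 nM in a functional assay on DU-145 cells (Homo sapiens) for inhibition, read by trypan blue exclusion, with a stated time of 96 h; a higher number here means a weaker inhibitor of growth, a lower number a stronger inhibitor of growth.
Compound 2 `Cc1ccc(S/C(=C/c2c(O)cc(O)cc2O)C(=O)c2ccc(Br)cc2)cc1` gives only a limit of this assay, > 100000 nM.
Compound 3 `Cc1ccc(S/C(=C/c2ccc(F)cc2F)C(=O)c2ccc(Br)cc2)cc1` gives only a limit of this assay, > 100000 nM.

Compound 3 therefore stands not at a number but at a limit of this assay, as does compound 2, and the measured values sit at the limit of > 100000 nM in this assay, at which 2 of the 3 values shown sit, for two of the three compounds. As far as these compounds go, the step from compound 1 reads as an at least 2.0-fold higher number from compound 1 to compound 3 (0.30 log units; that floor lies within the scatter), so the floor of that step lies within the scatter and the true size is unknown. The step between the two limits is a step that the two limits leave unreadable from compound 2 to compound 3. Compound 4 `CSc1ccc(/C=C(/Sc2ccc(C)cc2)C(=O)c2ccc(Br)cc2)cc1` differs from compound 3 in one place: 4-(methylsulfanyl)phenyl in place of 2,4-difluorophenyl on a double-bonded chain carbon bound to a double-bonded chain carbon. For the measured compounds named here, no measured step bears directly on a 4-(methylsulfanyl)phenyl group. Going by the values given here, the only measured compound with a number rather than a limit is compound 1, whose 4-acetylphenyl group sits on the same double-bonded chain carbon and which gives 50000 nM. Compound 4 is therefore expected to return toward that value, and the step from the limit is estimated as an at least 1.6-fold lower number from compound 3 to compound 4 (0.22 log units; that floor lies within the scatter), though a limit remains a real possibility. For compound 4 in this assay the estimate is 60000 nM, with a range from 25000 nM to 150000 nM.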

Compound 4, concentration for 50% growth inhibition: 50000 nM
Estimate against measurement, compound 4: 1.2-fold (0.08 log units) above, within the range that was stated.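

In this assay, the 4-(methylsulfanyl)phenyl group gives a second number rather than a limit at this place on the double-bonded chain carbon, though the floors of both steps from the limits lie within the scatter: an at least 2.0-fold lower number from compound 3 to compound 4 (0.30 log units; that floor lies within the scatter) and an at least 2.0-fold lower number from compound 2 to compound 4 (0.30 log units; that floor lies within the scatter). Methylsulfanyl in place of acetyl on an aromatic carbon gives no change at the digits printed from compound 1 to compound 4 (within the scatter), so these two groups cannot be told apart in this assay, and the value of compound 1 is no longer the only number in the set. Among these four compounds, the 4-acetylphenyl and 4-(methylsulfanyl)phenyl groups give numbers, while compound 2 and compound 3, with the 2,4,6-trihydroxyphenyl and 2,4-difluorophenyl groups, each stand at a limit and not at a number: the limit of > 100000 nM in this assay, at which 2 of the 4 values shown sit.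

As far as these compounds go, the true size of the steps from those limits stays open, and the step between the two limits cannot be read. Also open, from the compounds shown here alone, is how a carboxylic acid or an amine on the same phenyl ring at this place would compare with the methylsulfanyl and acetyl groups.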